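Benzothiazole thioacetamides: benzyl for methyl on the amide

The source may report more compounds than this note shows. Statements on the series, on what has been measured and on what is new or still open speak of the compounds shown alone.

Measured so far:
compound 1 `CC(=O)Nc1ccc2nc(SCC(=O)NCc3ccccc3)sc2c1`, 9200 nM
compound 2 `CNC(=O)CSc1nc2ccc(NC(=O)c3ccc(Cl)cc3)cc2s1`, 15300 nM

In a functional assay on HepG2 cells (Homo sapiens) for cytotoxicity, read by MTT assay, with a stated time of 48 h (on this read-out lower numbers stand for stronger inhibition and higher numbers for weaker inhibition), compound 2 gives 15300 nM, the higher of the two numbers, though its gap to compound 1 stays within the scatter. Compound 3 `O=C(CSc1nc2ccc(NC(=O)c3ccc(Cl)cc3)cc2s1)NCc1ccccc1` carries phenyl in place of hydrogen on a saturated chain carbon bound to an amide-type nitrogen, so the amide end matches compound 1 while the chlorobenzamide of compound 2 is kept. Among the measured compounds shown here, no measured pair covers this exact change. Compound 3 is expected to sit near or somewhat under compound 2, the step of a 1.7-fold lower number from compound 2 to compound 3 (0.23 log units; within the scatter) estimated as small and not clearly beyond the scatter. Compound 3 is thus estimated at 9000 nM, within 4000 nM to 25000 nM.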

Compound 3, half-maximal inhibitory concentration: 25400 nM
The estimate for compound 3 lay 2.8-fold (0.45 log units) below the measured number; the whole stated range lies below it.
By their numbers in this assay, from the lowest: compounds 1, 2 and 3 (each within the scatter of the next, the first and the last beyond it).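

With the chlorobenzamide end held, phenyl in place of hydrogen on the amide's methyl gives a 1.7-fold higher number from compound 2 to compound 3 (0.22 log units; within the scatter) in this assay and so does not separate benzyl from methyl at this position. Among the compounds shown here, with the benzyl amide held, 4-chlorophenyl in place of methyl on a carbonyl carbon gives a 2.8-fold higher number from compound 1 to compound 3 (0.44 log units; beyond the scatter) as the one step here beyond the scatter. No measurement bearing on the cause of either step is available.

Open, from the compounds shown here alone, is whether methyl to benzyl reads the same with the acetamide of compound 1. Also open, going by these compounds, is how a phenethyl chain or a carboxylic acid would read on the amide.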